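Methyl to ethyl on the pyrrole nitrogen of a side-chain acid

The source may hold more compounds than are shown below. What is called first, only, known or untested is meant among the compounds shown, and "the series" means these compounds.

Measured compounds:
compound 1, `CCn1c(C(=O)N[C@H](CO)CCO)ccc1C(CC)(CC)c1ccc(OCC(O)C(C)(C)C)c(C)c1`, 110 nM
compound 2, `CCC(CC)(c1ccc(OCC(O)C(C)(C)C)c(C)c1)c1ccc(C(=O)NCCC(=O)O)n1C`, 1600 nM

Compound 2 carries the higher of the two numbers in an assay on HL-60 cells for agonist activity at vitamin D3 receptor (Homo sapiens), with a stated time of 96 h; a lower number here means that less compound is needed, a higher number that more compound is needed for the effect. Compound 1 gives 110 nM, and compound 2 gives 1600 nM, a gap that lies beyond the scatter; the two structures differ in more than one place, so no single change can be read from this gap.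

Compound 3, `CCn1c(C(=O)NCCC(=O)O)ccc1C(CC)(CC)c1ccc(OCC(O)C(C)(C)C)c(C)c1`, is the unmeasured compound. It differs from compound 2 by methyl in place of hydrogen on a saturated chain carbon bound to an aromatic nitrogen. Among the measured compounds shown here, since no step between measured compounds isolates this change, the direction in this assay is open; compound 3 is expected to give a moderate step toward a lower number, a 2.0-fold lower number from compound 2 to compound 3 (0.30 log units; within the scatter), with compound 3 estimated at 800 nM, within a range from 250 nM to 2500 nM.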

Compound 3, half-maximal effective concentration: 33200 nM
Beside the measured number, compound 3's estimate is 42-fold (1.62 log units) below it, and the stated range ends below it.
By their numbers in this assay, from the lowest: compound 1; then compound 2; then compound 3.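

In this assay, adding one methyl on a saturated chain carbon bound to an aromatic nitrogen, with the 2-carboxyethyl side chain in place, gives a 21-fold higher number from compound 2 to compound 3 (1.32 log units; beyond the scatter) and so shows that this position is sensitive to a single added carbon. With the ethyl kept, exchanging 3-hydroxy-1-(hydroxymethyl)propyl for 2-carboxyethyl on the amide-type nitrogen gives a 300-fold higher number from compound 1 to compound 3 (2.48 log units; beyond the scatter) and shows that the side chain also weighs heavily on the number. Nothing available here accounts for either step. As far as these compounds go, whether a propyl chain at the same place would raise the number further, and whether methyl to ethyl would have the same effect alongside the 3-hydroxy-1-(hydroxymethyl)propyl side chain, stays open. So does the reading for a primary amide in place of the carboxylic acid.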